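A Bromine Added to a Second Core

The compounds below may be only part of what the source reports. "The series", "measured", "known", "first", "only" and "open" are said of these compounds alone.

compound 1 `COc1ccc(-c2cnnn2Cc2cc(OC)c(OC)c(OC)c2)cc1` — 5560 nM
compound 2 `COc1ccc(-c2cnnn2Cc2cc(OC)c(OC)c(OC)c2)cc1Br` — > 10000 nM
compound 3 `COc1ccc(-c2cn(Cc3cc(OC)c(OC)c(OC)c3)nn2)cc1` — > 10000 nM

In a functional assay on K562 cells (Homo sapiens) for cytotoxicity, read by MTT assay, with a stated time of 5 days (a lower number here means a stronger inhibitor, a higher number a weaker inhibitor), compound 1 gives 5560 nM. Compound 2 reaches only a limit of this assay, > 10000 nM, not a number. The change bromo in place of hydrogen on an aromatic carbon thus made an at least 1.7-fold higher number from compound 1 to compound 2 (0.25 log units; that floor lies within the scatter). Compound 3 has the same atoms as compound 1, joined differently; the difference between the two cores is not broken down here. Compound 3 also stops at a limit, > 10000 nM. Compound 4 `COc1ccc(-c2cn(Cc3cc(OC)c(OC)c(OC)c3)nn2)cc1Br` carries the same change, (bromo in place of hydrogen on an aromatic carbon), on the core of compound 3. Because the limit of > 10000 nM in this assay, at which 2 of the 3 values shown sit, already holds most of what is measured, the step is expected to be a step that the limit leaves unreadable from compound 3 to compound 4. Compound 4 is therefore estimated at 20000 nM, most likely between 8000 nM and 60000 nM.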

Compound 4, half-maximal inhibitory concentration: > 10000 nM
Compound 4 gave a limit, no number; the forecaster's own chance of this, stated with the estimate: 85%; the middle value lies beyond the limit too.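

For the compounds shown here, compound 3 and compound 4 both stop at a limit of the assay, so no step between them can be read. As far as these compounds go, whether 3-bromo-4-methoxyphenyl and 4-methoxyphenyl differ at all on this core stays open.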